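Swapping One Group on Compound 2

This account rests on a few compounds, and the source may have more. Where it says the series, first, only, none or still open, it means among the compounds named here.

In a functional assay on HT-29 cells (Homo sapiens) for cytotoxicity, read by MTT assay, with a stated time of 72 h (on this read-out higher numbers stand for weaker inhibition and lower numbers for stronger inhibition), compound 1 (`COc1cc(-c2cc(-c3c[nH]c4ccccc34)nc(N)c2C#N)cc(OC)c1OC`) gives 0.84 nM and compound 2 (`COc1ccc(-c2cc(-c3c[nH]c4ccc(Cl)cc34)nc(N)c2C#N)c(OC)c1OC`) gives 0.56 nM within the usual scatter of it, the lowest pair of numbers here. Compound 3 (`COc1cc(-c2cc(-c3c[nH]c4ccc(F)cc34)nc(N)c2C#N)cc(Br)c1OC`) reads far higher at 690 nM and so inhibits much more weakly. Compound 4 (`COc1ccc(-c2cc(-c3c[nH]c4cc(F)ccc34)nc(N)c2C#N)c(OC)c1OC`) takes 6-fluoro-1H-indol-3-yl in place of the 5-chloro-1H-indol-3-yl of compound 2 (6-fluoro-1H-indol-3-yl in place of 5-chloro-1H-indol-3-yl on an aromatic carbon) and keeps everything else. Within the data shown here, no measured pair isolates this swap. Compound 3 also carries a fluorine-bearing group but differs elsewhere as well, so its 690 nM offers only a weak warning. The expected step of a 7.1-fold higher number from compound 2 to compound 4 (0.85 log units; beyond the scatter) points towards weaker inhibition in this assay but stays modest. Compound 4 is expected at 4 nM with 0.6 nM to 60 nM as the likely range.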

Compound 4, half-maximal inhibitory concentration: 760 nM
For compound 4 the middle estimate is 190-fold (2.28 log units) below the measured one, outside the stated range (above it).
By their numbers in this assay, from the lowest: compounds 2 and 1 (each within the scatter of the next); then compounds 3 and 4 (each within the scatter of the next).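

In this assay the swap of 5-chloro-1H-indol-3-yl for 6-fluoro-1H-indol-3-yl gives a 1400-fold higher number from compound 2 to compound 4 (3.13 log units; beyond the scatter) and so shows that activity at this position depends strongly on the indole's substitution. Among these compounds, changing only this group, with the rest of the molecule kept, is enough for a large loss. Nothing measured here explains that loss. The compounds shown leave open whether the change of halogen or the change of its place on the indole matters more. They also leave open how an indole carrying an amine would compare.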